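Removing the Dimethylaminoethyl Chain from a Diaryl Ethylene

A few compounds are considered here, and "the series" means these few. Any claim that something is new, unique, unknown or untested is made for them only; others in the source may bear on it.

Compound 1 `COc1cc(OC)cc(C(=CC#N)c2ccc(OC)c(NC(C)=O)c2)c1`: 92 nM
Compound 2 `COc1cc(OC)cc(C(=CCCN(C)C)c2ccc(OC)c(OC)c2)c1`: > 10000 nM
Compound 3 `CCOc1cc(C(=CC#N)c2ccc(NC)cc2)ccc1OC`: 55 nM

In a functional assay on HCT-116 cells (Homo sapiens) for cytotoxicity, read by scintillation counting and thymidine incorporation, with a stated time of 72 h (a lower number here means a stronger inhibitor, a higher number a weaker inhibitor), compound 1 gives 92 nM and compound 3 gives 55 nM. Compound 2 reaches only a limit in this assay, > 10000 nM, and so sits at the limit of > 10000 nM in this assay, at which 1 of the 3 values shown sits, rather than at a number. Compound 4 `C=C(c1cc(OC)cc(OC)c1)c1ccc(OC)c(OC)c1` differs from compound 2 by hydrogen in place of 2-(dimethylamino)ethyl on a double-bonded chain carbon bound to a double-bonded chain carbon. Among the measured compounds shown here, no step between two measured compounds is available, and the two compounds that give numbers both carry a nitrile that compound 4 lacks, so the expectation rests on compound 2 alone. The step of an at least 3.3-fold lower number from compound 2 to compound 4 (0.52 log units; beyond the scatter) is expected to go toward stronger inhibition, though by an uncertain amount. Compound 4 is therefore estimated at 3000 nM, within a range from 300 nM to 12000 nM.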

Compound 4, half-maximal inhibitory concentration: > 10000 nM
Compound 4 gave a limit, no number (the forecaster's own chance of this, stated with the estimate: 35%); at least 3.3-fold (0.52 log units) between middle value and limit.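

Among the compounds shown here, no step from compound 2 to compound 4 can be read, since each gives only a limit and no number: the limit of > 10000 nM in this assay, at which 2 of the 4 values shown sit. The compounds shown leave open whether hydrogen in place of 2-(dimethylamino)ethyl changes inhibition at all.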